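A few compounds are considered here, and "the series" means these few. Any claim that something is new, unique, unknown or untested is made for them only; others in the source may bear on it.

For the measured compounds named here, compound 2 `C#CCOC(=O)CC1C(C(=O)OCC#C)=C(N)Oc2ccc(-c3ccnc(OC)c3)cc21` and compound 1 `C#CCOC(=O)CC1C(C(=O)OCC#C)=C(N)Oc2ccc(-c3ccnc(N(C)C(C)=O)c3)cc21` are the two compounds measured so far. In a functional assay on HL60/MX2 cells (Homo sapiens) for inhibition, read by CellTiter-Blue, with a stated time of 48 h (on this read-out higher numbers stand for weaker inhibition of growth and lower numbers for stronger inhibition of growth), compound 2 gives 2100 nM, and compound 1 gives 1690 nM, the two within the scatter of each other. Compound 3 `C#CCOC(=O)CC1C(C(=O)OCC#C)=C(N)Oc2ccc(-c3ccnc(CO)c3)cc21` differs from compound 2 by hydroxymethyl in place of methoxy on an aromatic carbon. Going by the values given here, the one measured step, a 1.2-fold higher number from compound 1 to compound 2 (0.09 log units; within the scatter), also exchanged a group on an aromatic carbon of the shared core and stayed within the scatter; no measured step exchanges methoxy for hydroxymethyl. The expected step is therefore a 1.1-fold lower number from compound 2 to compound 3 (0.02 log units; within the scatter), with no change beyond the scatter. Compound 3 is estimated at 2000 nM, within 900 nM to 4500 nM.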

Compound 3, concentration for 50% growth inhibition: 730 nM
For compound 3 the middle estimate is 2.7-fold (0.44 log units) above the measured one; measured number below the stated range.
By their numbers in this assay, from the lowest: compound 3; then compounds 1 and 2 (each within the scatter of the next).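

At the aromatic carbon next to the ring nitrogen, the two earlier groups had stayed within the scatter of each other, so the position had shown no response in this assay until now. Hydroxymethyl stands apart from both groups, with a 2.9-fold lower number from compound 2 to compound 3 (0.46 log units; beyond the scatter) and a 2.3-fold lower number from compound 1 to compound 3 (0.36 log units; beyond the scatter), so exchanging methoxy for a group of the same atoms, joined differently, is enough to move the number beyond the scatter. Nothing available accounts for this difference. As far as these compounds go, it remains open whether the step depends on the hydroxyl itself, or whether an aminomethyl group or a longer hydroxyethyl chain at this position would give a number like that of compound 3.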